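This account rests on a few compounds, and the source may have more. Where it says the series, first, only, none or still open, it means among the compounds named here.

Measured compounds:
Compound 1 `CC(/C=N/Nc1nc(N)c2ncn([C@@H]3O[C@H](CO)[C@@H](O)[C@H]3O)c2n1)Cc1ccc(C(C)C)cc1` gives 9500 nM in an assay on CHO-K1 cells for displacement of a labelled ligand from adenosine receptor A1 (Homo sapiens), read by scintillation counting, with a stated time of 60 min; a lower number here means a stronger inhibitor, a higher number a weaker inhibitor.
Compound 2 `N#Cc1ccc(/C=N/Nc2nc(N)c3ncn([C@@H]4O[C@H](CO)[C@@H](O)[C@H]4O)c3n2)cc1` gives 4.1 nM in this assay.

Of the two numbers in hand, compound 2 shows the lower one; compound 1 sits far higher, a gap beyond the usual scatter. Compound 3 `Nc1nc(N/N=C/c2ccc(N3CCCC3)cc2)nc2c1ncn2[C@@H]1O[C@H](CO)[C@@H](O)[C@H]1O` has not yet been measured in this assay. It differs from compound 2 in one place: pyrrolidin-1-yl in place of cyano on an aromatic carbon. Among the measured compounds shown here, no single-change step between measured compounds is available to anchor this change, so the expectation rests only on the two values shown. Compound 3 keeps the aromatic ring of compound 2 and is expected to stay well away from the weak number of compound 1, though the step of a 7.3-fold higher number from compound 2 to compound 3 (0.86 log units; beyond the scatter) is expected to run toward a somewhat higher number than compound 2 shows, beyond the scatter. Compound 3 is estimated at 30 nM, within a range of 5 nM to 200 nM.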

Compound 3, inhibition constant: 5.1 nM
Compound 3: middle estimate off by 5.9-fold (0.77 log units), on the high side, and the stated range covers the measured number.
By their numbers in this assay, from the lowest: compounds 2 and 3 (each within the scatter of the next); then compound 1.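

In this assay, putting pyrrolidin-1-yl in place of cyano on an aromatic carbon, para to a large group, gives a 1.2-fold higher number from compound 2 to compound 3 (0.09 log units; within the scatter) and leaves the two compounds indistinguishable. This single step shows that this position accepts the larger group, with its five-membered non-aromatic ring, in place of the triple-bonded nitrile, and no loss in binding can be read from the exchange. No measurement shown here explains why the two compounds match so closely.

As far as these compounds go, whether this holds beyond these two groups remains open, since a single pair cannot establish a trend at this position. An open-chain amine such as dimethylamino, a carboxylic acid or a methoxy group in the same place could still give quite different numbers, and a six-membered piperidine ring is equally untested here.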